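Trading the dimethylaminophenyl arm for a methoxyphenyl arm

A few compounds are considered here, and "the series" means these few. Any claim that something is new, unique, unknown or untested is made for them only; others in the source may bear on it.

Compound 1 `COc1ccc(C(=O)/C=C/c2ccc(N(C)C)cc2)c2c1C=CC(C)(C)O2` gives 570 nM in a functional assay on SW-620 cells (Homo sapiens) for antiproliferative activity, read by MTT assay, with a stated time of 24 h (on this read-out lower numbers stand for stronger inhibition and higher numbers for weaker inhibition), the lower of the two numbers shown, though the gap is within the scatter. Compound 2 `CCN(CC)c1ccc(/C=C/C(=O)c2ccc(OC)c3c2OC(C)(C)C=C3)cc1` gives 670 nM, and the step of a 1.2-fold higher number from compound 1 to compound 2 (0.07 log units; within the scatter) changes little. Compound 3 `COc1ccc(C(=O)/C=C/c2ccc(OC)c(OC)c2OC)c2c1C=CC(C)(C)O2` gives only a limit, > 10000 nM, as noted by the limit of > 10000 nM in this assay, at which 1 of the 3 values shown sits. Compound 4 `COc1ccccc1/C=C/C(=O)c1ccc(OC)c2c1OC(C)(C)C=C2` differs from compound 1 in one place: 2-methoxyphenyl in place of 4-(dimethylamino)phenyl on a double-bonded chain carbon bound to a double-bonded chain carbon. For the measured compounds named here, no measured step covers this change; the single measured step touched only the amino substituent and stayed within the scatter, while compound 3, whose arm carries methoxy groups, returns no number in this assay. A larger number is therefore expected for compound 4, with the estimated step of a 7.0-fold higher number from compound 1 to compound 4 (0.85 log units; beyond the scatter). Compound 4 is expected to give 4000 nM, ranging from 1000 nM to 15000 nM.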

Compound 4, half-maximal inhibitory concentration: > 10000 nM
Compound 4 was reported as a limit; the forecaster's own chance of this, stated with the estimate: 35%; middle value at least 2.5-fold (0.39 log units) away from the limit.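

In this assay, for the compounds shown here, 2-methoxyphenyl in place of 4-(dimethylamino)phenyl gives an at least 17-fold higher number from compound 1 to compound 4 (1.24 log units; beyond the scatter), the first step at this position that lies beyond the scatter. Compound 4 is reported only as a limit, and it is the second compound there: the limit of > 10000 nM in this assay, at which 2 of the 4 values shown sit. Among the compounds shown, both amino-bearing arms give numbers and both methoxy-bearing arms give limits, with no exception.

The compounds shown leave open whether the loss follows from removing the dimethylamino group or from adding the methoxy group. They also leave open whether an arm carrying a pyrrolidine or a primary amine would give a number.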